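The compounds below may be only part of what the source reports. "The series", "measured", "known", "first", "only" and "open" are said of these compounds alone.

Among the measured compounds shown here, in a functional assay on SW-620 cells (Homo sapiens) for cytotoxicity (a lower number here means a stronger inhibitor, a higher number a weaker inhibitor), compound 3 `O=C(CCCCCCC(=O)Nc1nc2ccc([N+](=O)[O-])cc2s1)NO` gives 0.29 ug/mL, the lowest of the three numbers measured so far. Compound 1 `O=C(CCCCC(=O)Nc1nc2ccccc2s1)NO` gives 7.85 ug/mL and compound 2 `COc1ccc2nc(NC(=O)CCCCC(=O)NO)sc2c1` gives 9.07 ug/mL; each differs from compound 3 in more than one place, so the gap to them cannot be pinned on a single change. For the measured compounds named here, the only single-change step measured, a 1.2-fold higher number from compound 1 to compound 2 (0.06 log units; within the scatter), sits on the aromatic ring and does not touch the chain. Compound 4 `O=C(CCCCC(=O)Nc1nc2ccc([N+](=O)[O-])cc2s1)NO` arises from compound 3 by hydroxycarbamoyl in place of 2-(hydroxycarbamoyl)ethyl on a saturated chain carbon, four bonds along the chain from a carbonyl carbon. Going by the values given here, no measured step bears directly on this change, so its direction remains open. Since compound 4 shares one part with compound 3 and another with compound 1, compound 4 is estimated at 2 ug/mL, with a range from 0.5 ug/mL to 8 ug/mL. This implies an expected step of a 6.9-fold higher number from compound 3 to compound 4 (0.84 log units; beyond the scatter).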

Compound 4, half-maximal inhibitory concentration: > 30 ug/mL
Compound 4: only a limit was reported; the forecaster's own chance of this, stated with the estimate: 5%; middle value at least 15-fold (1.17 log units) from the limit.
By their numbers in this assay, from the lowest: compound 3; then compounds 1 and 2 (each within the scatter of the next). At a limit, above all of these: compound 4.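

In this assay this chain position proves sensitive: hydroxycarbamoyl in place of 2-(hydroxycarbamoyl)ethyl gives an at least 100-fold higher number from compound 3 to compound 4 (2.01 log units; beyond the scatter). With the chain held the same, the ring group also counts: nitro in place of hydrogen gives an at least 3.8-fold higher number from compound 1 to compound 4 (0.58 log units; beyond the scatter), and nitro in place of methoxy gives an at least 3.3-fold higher number from compound 2 to compound 4 (0.51 log units; beyond the scatter), although methoxy in place of hydrogen stayed within the scatter. Compound 4 carries a limit, not a number: the limit of > 30 ug/mL in this assay, at which 1 of the 4 values shown sits.

Still open, going by these compounds, is how the chain change behaves with hydrogen or methoxy on the ring. Also open, on these data alone, is whether a longer chain, or an amine in place of nitro, would keep the low number of compound 3.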